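Removing the nitrogen methyl from compound 3

A few compounds are considered here, and "the series" means these few. Any claim that something is new, unique, unknown or untested is made for them only; others in the source may bear on it.

In a functional assay on A549 cells (Homo sapiens) for cytotoxicity, read by MTT assay, with a stated time of 72 h (a lower number here means a stronger inhibitor, a higher number a weaker inhibitor), compound 1 (`Cn1ccc2c(Oc3ccc(NC(=O)c4cc5cccnc5n(-c5ccc(C(F)(F)F)cc5Cl)c4=O)cc3)ncnc21`) gives 364000 nM as its reading and compound 2 (`Cn1ccc2c(Oc3ccc(NC(=O)c4cc5cccnc5n(-c5ccc(C(F)(F)F)c(Cl)c5)c4=O)cc3F)ncnc21`) gives 320000 nM as its reading, two values within the scatter of each other. Compound 3 (`Cn1ccc2c(Oc3ccc(NC(=O)c4cc5cccnc5n(-c5ccc(C(F)(F)F)cc5Cl)c4=O)cc3F)ncnc21`) is reported as "not active" (no number reported) with no number, so it has no place on the scale. Among the measured compounds shown here, the only numbers are those of compound 1 and compound 2. Compound 4 (`O=C(Nc1ccc(Oc2ncnc3[nH]ccc23)c(F)c1)c1cc2cccnc2n(-c2ccc(C(F)(F)F)cc2Cl)c1=O`) differs from compound 3 by a single change: hydrogen in place of methyl on an aromatic nitrogen. For the measured compounds named here, no measured pair shows this change, and compound 3 offers no number to step from. A moderate step toward stronger inhibition, beyond the scatter, is expected, though this rests on little and another result without a number remains possible. In this assay the estimated value for compound 4 is 50000 nM with an expected range from 3000 nM to 400000 nM for now.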

Compound 4, half-maximal inhibitory concentration: 283000 nM
The estimate for compound 4 lay 5.7-fold (0.75 log units) below the measured number; the measured number falls inside the stated range.
By their numbers in this assay, from the lowest: compounds 4, 2 and 1 (each within the scatter of the next).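

Among the compounds shown here, compound 3 carries no number in this assay and compound 4 gives 283000 nM, so no step between the two can be read. The compounds shown leave open what swapping methyl for hydrogen on the aromatic nitrogen does to the reading. No supporting evidence bears on this result.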